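Furan for Pyridine Ester Swap on Two Related Cores

The source may hold more compounds than are shown below. What is called first, only, known or untested is meant among the compounds shown, and "the series" means these compounds.

Compound 1 `C=C1CC[C@@H]2[C@](C)(COC(=O)c3cccnc3)[C@H](O)CC[C@@]2(C)[C@@H]1/C=C/C1=CCOC1=O` and compound 2 `C=C1CC[C@@H]2[C@](C)(COC(=O)c3ccco3)[C@H](O)CC[C@@]2(C)[C@@H]1/C=C/C1=CCOC1=O` share one core, while compound 3 `C=C1CC[C@@H]2[C@](C)(CO)[C@H](OC(=O)c3cccnc3)CC[C@@]2(C)[C@@H]1C/C=C1\C=COC1=O` is built on a different core; the difference between the two cores is not broken down here. In an ADME assay on HepG2 2.2.15 cells (Homo sapiens) for cytotoxicity, read by MTT assay (on this read-out higher numbers stand for lower toxicity in this test and lower numbers for higher toxicity in this test), compound 1 gives 113000 nM, and compound 2 gives 92000 nM. The change between them, (furan-2-yl in place of pyridin-3-yl on a carbonyl carbon), made a step of a 1.2-fold lower number from compound 1 to compound 2 (0.09 log units; within the scatter). In this assay compound 3 gives 337000 nM, the highest number of the three measured compounds. Compound 4 `C=C1CC[C@@H]2[C@](C)(CO)[C@H](OC(=O)c3ccco3)CC[C@@]2(C)[C@@H]1C/C=C1\C=COC1=O` carries the same change on the core of compound 3, namely (furan-2-yl in place of pyridin-3-yl on a carbonyl carbon). For the measured compounds named here, because the step of a 1.2-fold lower number from compound 1 to compound 2 (0.09 log units; within the scatter) stayed small, the step from compound 3 to compound 4 is expected to be similar in size, a 1.2-fold lower number from compound 3 to compound 4 (0.07 log units; within the scatter), with the caution that only one such pair has been measured and that the core of compound 3 is not the core of compound 1. Compound 4 is therefore estimated at 290000 nM, with a likely range from 140000 nM to 600000 nM.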

Compound 4, half-maximal cytotoxic concentration: 42000 nM
Compound 4: the middle estimate sits 6.9-fold (0.84 log units) above what was measured; the measured number lies below the stated range.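

On the core of compound 3, furan-2-yl in place of pyridin-3-yl on a carbonyl carbon produced an 8.0-fold lower number from compound 3 to compound 4 (0.90 log units; beyond the scatter) in this assay, so compound 4 reads as more toxic in this test than compound 3. The same change therefore did not carry over in size from one core to the other, and the two steps differ clearly: the same change on two cores in this assay, a 1.2-fold lower number (0.09 log units; within the scatter) from compound 1 to compound 2 and an 8.0-fold lower number (0.90 log units; beyond the scatter) from compound 3 to compound 4, 6.5-fold (0.82 log units) apart, beyond the scatter of two such steps

For the compounds shown here, this shows that, in this series, a step measured on one core cannot be assumed to hold on another, but it does not show which feature of the two cores sets the difference, and with only one pair per core it gives no general rule.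

The compounds shown leave open whether other groups on the same carbonyl carbon, such as a phenyl ring or a short alkyl chain, would also give steps that differ between these two cores. On these data alone, how the same change would read on a third core also remains open.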